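Series notes: acyl change on the shared core, compound 1 to 4

This account rests on a few compounds, and the source may have more. Where it says the series, first, only, none or still open, it means among the compounds named here.

Measured so far:
compound 1 `COc1ccc(C(=O)N2CCN(Cc3nc4ccccc4n3Cc3cccc(C)c3)CC2)cc1` — 55.5%
compound 2 `O=C(C1CC1)N1CCN(Cc2nc3ccccc3n2Cc2ccccc2C(F)(F)F)CC1` — 56.3%
compound 3 `Cc1ccccc1Cn1c(CN2CCN(C(=O)C3CC3)CC2)nc2ccccc21` — 29.1%

In an assay on isolated protein for inhibition of aldehyde dehydrogenase 1A1 (Homo sapiens), read by spectrophotometry, tested at 10 uM (a lower number here means less inhibition, a higher number more inhibition at the concentration tested (going by the name of the read-out)), compound 1 gives 55.5%, the second highest of the three numbers. Compound 2 gives 56.3%, within the scatter of compound 1; compound 3 gives 29.1%, beyond the scatter below both. Among the measured compounds shown here, the only single-point step recorded is a number 27.2 percentage points lower from compound 2 to compound 3 (beyond the scatter), a methyl in place of trifluoromethyl on an aromatic carbon of the benzyl group; it does not touch the acyl part of the core. Compound 1 and compound 2 differ in more than one place, so their two values show only that they lie close together.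

Compound 4 `Cc1cccc(Cn2c(CN3CCN(C(=O)c4cccnc4)CC3)nc3ccccc32)c1` differs from compound 1 as follows: pyridin-3-yl in place of 4-methoxyphenyl on a carbonyl carbon. For the measured compounds named here, no measured step involves a change on the carbonyl carbon, so nothing here says how this assay responds to swapping the group on the amide carbonyl. The expectation is therefore anchored on compound 1 and kept wide: a step of a number 10.5 percentage points lower from compound 1 to compound 4 (beyond the scatter) is estimated, with no firm direction. Compound 4 is expected to give about 45%, in the range 20% to 70%.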

Compound 4, a percentage reported as inhibition, at one concentration (the size of the read-out at that concentration, not a potency): 24.5%
Compound 4: middle estimate off by 20.5 percentage points, on the high side; measured number inside the range.
By their numbers in this assay, from the lowest: compounds 4 and 3 (each within the scatter of the next); then compounds 1 and 2 (each within the scatter of the next).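

The group on the carbonyl carbon matters in this assay. Among the compounds shown here, this is the first measured change at that place, and a number 31 percentage points lower from compound 1 to compound 4 (beyond the scatter) with the rest of the molecule held constant. The earlier step on the benzyl group left the acyl part untouched, so the series now has a measured response on each of these two sides of the shared core. Pyridin-3-yl in place of 4-methoxyphenyl leaves the count of hydrogen-bond acceptors unchanged at the level printed for the two groups, so that count does not separate them, and nothing available bears on why this swap shifts the read-out.

Two differences travel together in this one step, the ring nitrogen entering and the methoxy group leaving, and a plain phenyl or a 4-methylphenyl on the carbonyl carbon would be needed to tell them apart. Going by these compounds, it also remains open whether the same swap gives a step of similar size with a trifluoromethyl-bearing benzyl group, or whether a pyridin-4-yl or a cyclopropyl on the carbonyl carbon would stay with compound 1 or with compound 4.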